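Ring-opened amine substituent: working notes toward compound 4

This account rests on a few compounds, and the source may have more. Where it says the series, first, only, none or still open, it means among the compounds named here.

Measured so far in an assay on isolated protein for inhibition of DNA topoisomerase 1 (Homo sapiens), with a stated time of 15 min; on this read-out lower numbers stand for stronger inhibition and higher numbers for weaker inhibition:
compound 1 `CN[C@@H]1CCN(c2cc3c(cc2F)c(=O)c(C(=O)O)cn3Cc2ccc(-c3ccccc3)cc2)C1` gives 34800 nM.
compound 2 `CN[C@@H]1CCN(c2c(F)cc3c(=O)c(C(=O)O)cn(Cc4ccc(-c5ccccc5)cc4)c3c2OC)C1` gives 57700 nM.
compound 3 `COc1c(N2CC[C@@H](CN)C2)c(F)cc2c(=O)c(C(=O)O)cn(Cc3ccc(-n4cccn4)cc3)c12` gives > 200000 nM, which is a limit of the assay and not a number.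

Compound 1 holds the lowest of the two numbers; its nearest neighbour is compound 2, and the step of a 1.7-fold higher number from compound 1 to compound 2 (0.22 log units; within the scatter), methoxy in place of hydrogen on an aromatic carbon, stays within the scatter. For compound 3 only the limit of > 200000 nM in this assay, at which 1 of the 3 values shown sits, stands, so compound 3 cannot be placed relative to the others.

Compound 4 `NCCNc1cc2c(cc1F)c(=O)c(C(=O)O)cn2Cc1ccc(-c2ccccc2)cc1` differs from compound 1 in one place: (2-aminoethyl)amino in place of 3-(methylamino)pyrrolidin-1-yl on an aromatic carbon. Among the compounds with values here, no measured step touches this substituent; the single step in hand concerns a methoxy group elsewhere on the shared core and was within the scatter. The expectation for compound 4 in this assay therefore rests on the structural change alone, with the open-chain amine expected to give a somewhat higher number than compound 1, though within a wide band. Compound 4 is estimated at 55000 nM, between 15000 nM and 200000 nM. This estimate means a step of a 1.6-fold higher number from compound 1 to compound 4 (0.20 log units; within the scatter), expected to sit near the edge of the scatter, with a real chance that only a limit is returned.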

Compound 4, half-maximal inhibitory concentration: 72800 nM
Compound 4: middle estimate off by 1.3-fold (0.12 log units), on the low side; low and high end bracket the measured number.
By their numbers in this assay, from the lowest: compounds 1, 2 and 4 (each within the scatter of the next, the first and the last beyond it). At a limit, above all of these: compound 3.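

In this assay, within the data shown here, the first measured change on this aromatic carbon, ortho to a fluoro group, gives a 2.1-fold higher number from compound 1 to compound 4 (0.32 log units; beyond the scatter), with (2-aminoethyl)amino in place of 3-(methylamino)pyrrolidin-1-yl. The substituent therefore need not keep its five-membered ring or its defined stereocentre for a number to be returned: compound 4, with no ring, gives 72800 nM, which is a number and not a limit of the assay, although the step is modest and lies just beyond the scatter. No measurement shown offers a reason for the size of this step.

This single pair changes the ring, the stereocentre and the heavy-atom count together, so the contribution of each to the step remains unresolved. Also open, as far as these compounds go, are whether a longer chain such as (3-aminopropyl)amino, or a terminal dimethylamino group on the same two-carbon chain, would move the number in either direction, and whether the (2-aminoethyl)amino group would give a similar step on the methoxy-bearing core of compound 2.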